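Triazole series: enantiomer of compound 2 in cytotoxicity

The compounds below may be only part of what the source reports. "The series", "measured", "known", "first", "only" and "open" are said of these compounds alone.

Measured so far:
compound 1, `CC[C@@H](CCn1cncn1)c1ccc(F)cc1`: 91.6 ug/mL
compound 2, `CCC[C@H](CCn1cncn1)c1ccc(F)cc1`: 38.4 ug/mL

In an ADME assay on RD cells (Homo sapiens) for cytotoxicity, read by MTT assay, with a stated time of 3 days (on this read-out lower numbers stand for higher toxicity in this test and higher numbers for lower toxicity in this test), compound 2 gives 38.4 ug/mL, the lowest of the two numbers in hand. Its nearest neighbour is compound 1, which in this assay gives 91.6 ug/mL, a higher number, and the gap between compound 2 and compound 1 lies beyond the usual scatter. Compound 1 and compound 2 differ in more than one place, so only their two values are compared here, without a computed step.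

The next compound is compound 3, `CCC[C@@H](CCn1cncn1)c1ccc(F)cc1`, to be measured in this assay. Compound 3 differs from compound 2 as follows: the two compounds have the same atoms and bonds and differ only in configuration as drawn: 1 of 1 stereo elements differ; a stereocentre at a saturated chain carbon is drawn R in compound 2 and S in compound 3. Within the data shown here, no step between two measured compounds of this kind is available, so the size of the expected step has to be set from the two values alone.

With only the configuration as drawn changed, the number for compound 3 is expected to stay close to that of compound 2, with a step of a 1.3-fold higher number from compound 2 to compound 3 (0.11 log units; within the scatter) that is expected to fall within or near the scatter. Compound 3 is thus estimated at 50 ug/mL, in the range 25 ug/mL to 100 ug/mL.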

Compound 3, half-maximal cytotoxic concentration: 56.9 ug/mL
The estimate for compound 3 lay 1.1-fold (0.06 log units) below the measured number; measured number inside the range.
By their numbers in this assay, from the lowest: compounds 2, 3 and 1 (each within the scatter of the next, the first and the last beyond it).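

In this assay, among these compounds, the swap of configuration at the saturated chain carbon gives a 1.5-fold higher number from compound 2 to compound 3 (0.17 log units; within the scatter), so at this position the drawn configuration produces no step that can be told apart from the scatter in this one pair, which is the cleanest comparison so far: the fact that compounds 2 and 3 differ only in the configuration as drawn. The other single change, methyl in place of hydrogen on a saturated chain carbon, three bonds along the chain from an aromatic carbon, gives a 1.6-fold lower number from compound 1 to compound 3 (0.21 log units; within the scatter). Both steps through compound 3 are therefore unresolved, and the series now holds two single changes on this chain, neither of which separates its pair in this read-out.

The compounds shown leave open whether a larger change at this chain, such as a longer chain, a hydroxyl or an amine, would give a step beyond the scatter in this assay. They also leave open how the number responds when the fluoro substituent on the aromatic ring gives way to a chloro or methoxy group, or when the triazole end of the chain is replaced by an imidazole.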